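Swapping Methoxy for Ethoxycarbonyl on the Aromatic Ring

The compounds below may be only part of what the source reports. "The series", "measured", "known", "first", "only" and "open" are said of these compounds alone.

In a functional assay on the whole organism with Rattus norvegicus as the target (a higher number here means that more compound is needed for the effect, a lower number that less compound is needed), compound 1 `CCOCCOC(=O)C(=O)Nc1nc(-c2cc(OC)no2)cs1` gives 11 mg/kg. Compound 2 `CCOC(=O)C(=O)Nc1nc(-c2cc(C)no2)cs1` gives 0.7 mg/kg, so compound 1 has the higher of the two numbers, well beyond the scatter. Compound 3 `O=C(Nc1nc(-c2cc(-c3c(F)cccc3Cl)no2)cs1)C(=O)OCc1ccccc1` is reported only as a limit, > 30 mg/kg. Compound 4 `CCOCCOC(=O)C(=O)Nc1nc(-c2cc(C(=O)OCC)no2)cs1` keeps the ester of compound 1 but carries ethoxycarbonyl in place of methoxy on an aromatic carbon, next to the ring nitrogen (ethoxycarbonyl in place of methoxy on an aromatic carbon). Going by the values given here, no two measured compounds differ in one place only, so little guides the forecast in this assay. A small move toward a lower number, within the scatter, is expected. The expected step is a 1.4-fold lower number from compound 1 to compound 4 (0.14 log units; within the scatter). For compound 4 the estimated value is 8 mg/kg, with an expected range of 2 mg/kg to 30 mg/kg.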

Compound 4, dose for half-maximal effect: 1.9 mg/kg
Beside the measured number, compound 4's estimate is 4.2-fold (0.62 log units) above it; measured number outside the range, below it.
By their numbers in this assay, from the lowest: compound 2; then compound 4; then compound 1. At a limit, above all of these: compound 3.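

At this position, next to the ring nitrogen, this assay gives the only single-place comparison among the compounds shown: ethoxycarbonyl in place of methoxy brings a 5.8-fold lower number from compound 1 to compound 4 (0.76 log units; beyond the scatter). The position therefore accepts the larger ester group with less compound needed for the effect, not more. Nothing in the data shown bears on why the number falls. Still open, going by these compounds, is whether a carboxylic acid or a primary amide at this position would keep the lower number. On these data alone, it is also open whether a longer ester chain would do so.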